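Trifluoromethyl on the Fused Ring of Compound 3

The source may hold more compounds than are shown below. What is called first, only, known or untested is meant among the compounds shown, and "the series" means these compounds.

Compound 1 `COc1ccccc1-n1nc(C(=O)NCC(=O)Nc2nc3ccccc3s2)c2ccccc2c1=O` gives 10000 nM in an assay on L cells for inhibition of Protein-serine O-palmitoleoyltransferase porcupine (Mus musculus), read by reporter gene assay, with a stated time of 24 h; on this read-out lower numbers stand for an effect already at smaller amounts and higher numbers for an effect only at larger amounts of compound.
Compound 2 `COc1ccc(-n2nc(C(=O)NCC(=O)Nc3nc4ccccc4s3)c3ccccc3c2=O)cc1` gives 25000 nM in this assay.
Compound 3 `O=C(CNC(=O)c1nn(-c2ccc(F)cc2)c(=O)c2ccccc12)Nc1nc2ccccc2s1` in this assay reports only a limit, > 25000 nM.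

Compound 3 thus stands at the weak end of the measured set: an at least 2.5-fold higher number from compound 1 to compound 3 (0.39 log units; beyond the scatter), and a number no lower from compound 2 to compound 3 (the limit leaves the size open). Compound 4 `O=C(CNC(=O)c1nn(-c2ccc(F)cc2)c(=O)c2ccccc12)Nc1nc2ccc(C(F)(F)F)cc2s1` differs from it by trifluoromethyl in place of hydrogen on an aromatic carbon. Among the measured compounds shown here, none of the measured steps touches this place; all three alter the group on the aromatic nitrogen, so no direction can be read for this change in this assay. Compound 4 is therefore expected to sit near the limit of compound 3, estimated at 25000 nM with a range from 8000 nM to 80000 nM. This estimate means the step of a number no higher from compound 3 to compound 4 (the limit leaves the size open), which is expected to stay within the scatter.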

Compound 4, half-maximal effective concentration: 90 nM
The estimate for compound 4 lay 280-fold (2.44 log units) above the measured number; measured number below the stated range.
By their numbers in this assay, from the lowest: compound 4; then compound 1; then compound 2.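

Among the compounds shown here, at this aromatic carbon of the fused system, which no earlier step touched, trifluoromethyl in place of hydrogen gives an at least 270-fold lower number from compound 3 to compound 4 (2.44 log units; beyond the scatter), well beyond the modest steps seen on the aromatic nitrogen in this assay. A change at this place can therefore move the read-out far more than any readable change of the group on that nitrogen. The value of compound 3 is a limit of the assay, not a number: the limit of > 25000 nM in this assay, at which 1 of the 4 values shown sits.

As far as these compounds go, whether chloro, a nitrile or an amine at this carbon would act like trifluoromethyl stays open. So does whether the gain carries over to the 2-methoxyphenyl group of compound 1.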